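Bromo on the indole ring of a cyanodienone series

A few compounds are considered here, and "the series" means these few. Any claim that something is new, unique, unknown or untested is made for them only; others in the source may bear on it.

Measured in a functional assay on MCF7 cells (Homo sapiens) for cytotoxicity, read by sulforhodamine B assay, with a stated time of 48 h (a higher number here means a weaker inhibitor of growth, a lower number a stronger inhibitor of growth), so far:
Compound 1, `COc1ccc(/C(Cl)=C/C=C(\C#N)C(=O)c2c[nH]c3ccc(Br)cc23)cc1`, gives 80300 nM.
Compound 2, `COc1ccc2[nH]cc(C(=O)/C(C#N)=C/C=C(\Cl)c3ccc(Br)cc3)c2c1`, gives 79900 nM.
Compound 3, `N#C/C(=C\C=C(/Cl)c1ccc(Br)cc1)C(=O)c1c[nH]c2ccccc12`, gives 72500 nM.

The three numbers sit close together. Among the compounds with values here, compound 3 has the low end of the trio, but its gaps to compound 2 and compound 1 are both within the usual scatter, so no compound can be set apart from the others. Within the data shown here, the only step between compounds differing in a single place is a 1.1-fold lower number from compound 2 to compound 3 (0.04 log units; within the scatter), hydrogen in place of methoxy on an aromatic carbon, and it changed nothing beyond the scatter.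

Compound 4, `N#C/C(=C\C=C(/Cl)c1ccc(Br)cc1)C(=O)c1c[nH]c2ccc(Br)cc12`, carries bromo in place of hydrogen on an aromatic carbon. Among the measured compounds shown here, no single-place step with a bromo entering exists among the measured compounds; compound 1, which bears a bromo at that same position of its core together with a methoxy elsewhere, and compound 3 show values within the scatter of each other, which is the nearest hint available. For the measured compounds named here, with the one known step flat and no contrary sign, the expected step of a 1.0-fold higher number from compound 3 to compound 4 (0.01 log units; within the scatter) is none beyond the scatter. Compound 4 is therefore estimated at 75000 nM in this assay, within the range 35000 nM to 160000 nM.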

Compound 4, concentration for 50% growth inhibition: > 100000 nM
Compound 4 was reported as a limit (the forecaster's own chance of this, stated with the estimate: 5%); middle value at least 1.3-fold (0.12 log units) from the limit.
By their numbers in this assay, from the lowest: compounds 3, 2 and 1 (each within the scatter of the next). At a limit, above all of these: compound 4.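

In this assay compound 4 is reported only as a limit, > 100000 nM. At this position, bromo in place of hydrogen gives an at least 1.3-fold higher number from compound 3 to compound 4 (0.13 log units; that floor lies within the scatter), and bromo in place of methoxy at the same aromatic carbon gives an at least 1.2-fold higher number from compound 2 to compound 4 (0.09 log units; that floor lies within the scatter), while bromo in place of methoxy at another aromatic carbon gives an at least 1.2-fold higher number from compound 1 to compound 4 (0.09 log units; that floor lies within the scatter). Hydrogen and methoxy at this position had both given measured numbers, and so had bromo with a methoxy elsewhere, but with compound 4 the series reaches a limit for the first time, and each of these steps is a floor only, not a size, because the value of compound 4 is a limit and each floor lies within the scatter: the limit of > 100000 nM in this assay, at which 1 of the 4 values shown sits.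

The compounds shown therefore leave open how far compound 4 really stands from the other three, and whether the bromo step at this position goes beyond the scatter at all. They also leave open what a fluoro, an amine or a carboxylic acid on this aromatic carbon would do to the number.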